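Replacing pyrimidin-2-yl with 5-methyl-1,2,4-oxadiazol-3-yl

A few compounds are considered here, and "the series" means these few. Any claim that something is new, unique, unknown or untested is made for them only; others in the source may bear on it.

Three compounds sharing one core have been followed in an ADME assay on the whole organism (Mus musculus, strain ICR) for metabolic stability, at a dose of 50 mg/kg by the oral route; a higher number here means that the compound lasts longer, a lower number that the compound disappears faster. Compound 1 `N#CC1CC(=O)N(c2cnn3c2CN(C(=O)Nc2cc(F)c(F)c(F)c2)C(C2CC2)C3)C1`, which carries a cyano group, gives 4.63 h. Compound 2 `O=C1CC(c2ncco2)CN1c1cnn2c1CN(C(=O)Nc1cc(F)c(F)c(F)c1)C(C1CC1)C2`, with 1,3-oxazol-2-yl, gives 3.7 h. Compound 3 `O=C1CC(c2ncccn2)CN1c1cnn2c1CN(C(=O)Nc1cc(F)c(F)c(F)c1)C(C1CC1)C2`, with pyrimidin-2-yl, gives 0.87 h, the lowest of the three.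

Compound 4 `Cc1nc(C2CC(=O)N(c3cnn4c3CN(C(=O)Nc3cc(F)c(F)c(F)c3)C(C3CC3)C4)C2)no1` has 5-methyl-1,2,4-oxadiazol-3-yl in place of pyrimidin-2-yl on a saturated ring carbon. Among the compounds with values here, no measured step makes this exact change. The entry of pyrimidin-2-yl gave modest steps, a 4.3-fold lower number from compound 2 to compound 3 (0.63 log units; beyond the scatter) and a 5.3-fold lower number from compound 1 to compound 3 (0.73 log units; beyond the scatter), whereas 1,3-oxazol-2-yl in place of cyano gave only a 1.3-fold lower number from compound 1 to compound 2 (0.10 log units; within the scatter). Like compound 2 at 3.7 h, compound 4 bears a five-membered aromatic ring, so part of the gap is expected to close, though the methyl group remains untested. The expected change is modest, a 2.8-fold higher number from compound 3 to compound 4 (0.44 log units; beyond the scatter). The estimated half-life for compound 4 is 2.4 h, with an expected range of 1 h to 5 h.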

Compound 4, half-life: 3.37 h
Beside the measured number, compound 4's estimate is 1.4-fold (0.15 log units) below it, within the range that was stated.
By their numbers in this assay, from the lowest: compound 3; then compounds 4, 2 and 1 (each within the scatter of the next).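

In this assay, a second five-membered aromatic ring at this saturated ring carbon, 5-methyl-1,2,4-oxadiazol-3-yl, gives a 3.9-fold higher number from compound 3 to compound 4 (0.59 log units; beyond the scatter), so the low number of compound 3 does not carry over to this group of the same heavy-atom count. Set against the other two groups, the new ring gives a 1.1-fold lower number from compound 2 to compound 4 (0.04 log units; within the scatter) and a 1.4-fold lower number from compound 1 to compound 4 (0.14 log units; within the scatter), both within the scatter, which leaves compound 3 alone apart from the other three among these four compounds. Nothing available here explains this difference between pyrimidin-2-yl and the other groups.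

The compounds shown leave open what the methyl group of compound 4 contributes, a question the unsubstituted 1,2,4-oxadiazol-3-yl would address. They also leave open whether pyridin-2-yl or phenyl at this carbon would give a number near that of compound 3 or near those of the other three.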